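Replacing Nitro with Chloro: Weaker Cytotoxicity Expected

The source may report more compounds than this note shows. Statements on the series, on what has been measured and on what is new or still open speak of the compounds shown alone.

In a functional assay on A549 cells (Homo sapiens) for cytotoxicity, read by CCK-8 assay, with a stated time of 24 h (on this read-out lower numbers stand for stronger inhibition and higher numbers for weaker inhibition), three compounds of a shared core have been examined. Compound 1 `C/C(=C\c1cc(-c2ccccc2)cs1)C(N)=O` gives > 50000 nM, which is a limit of the assay and not a number. Compound 2 `C/C(=C\c1cc(-c2ccc(C)cc2)cs1)C(N)=O` likewise gives only the limit > 50000 nM. Among the compounds with values here, compound 3 `C/C(=C\c1cc(-c2ccc([N+](=O)[O-])cc2)cs1)C(N)=O` gives 3500 nM, and so stands as the only read value among the three, the other two sitting at the limit of > 50000 nM in this assay, at which 2 of the 3 values shown sit. The step of an at least 14-fold lower number from compound 1 to compound 3 (1.15 log units; beyond the scatter) and the step of an at least 14-fold lower number from compound 2 to compound 3 (1.15 log units; beyond the scatter) are both large and beyond the scatter, whereas the step that the two limits leave unreadable from compound 1 to compound 2 is unreadable because the limit of > 50000 nM in this assay, at which 2 of the 3 values shown sit, holds both of its ends.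

Compound 4 `C/C(=C\c1cc(-c2ccc(Cl)cc2)cs1)C(N)=O` has not yet been measured; it differs from compound 3 by chloro in place of nitro on an aromatic carbon. The two readable steps bear directly on it: each time nitro entered on that aromatic carbon the number fell by a large margin, and compound 4 gives the nitro up. Chloro is neither hydrogen nor methyl, so the loss need not reach the full gap, but in this assay an upward step is expected, estimated as a 5.7-fold higher number from compound 3 to compound 4 (0.76 log units; beyond the scatter). Compound 4 is therefore expected to show about 20000 nM, within a range from 5000 nM to 60000 nM, with a fair chance that only a limit is reported.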

Compound 4, half-maximal inhibitory concentration: > 50000 nM
Compound 4: no number, only a limit; the forecaster's own chance of this, stated with the estimate: 40%; at least 2.5-fold (0.39 log units) between middle value and limit.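

In this assay, the change of nitro to chloro on this aromatic carbon, para to a large group, gives an at least 14-fold higher number from compound 3 to compound 4 (1.15 log units; beyond the scatter), so the low number of compound 3 is not kept when a different substituent takes the place of the nitro. The earlier compounds had set nitro only against hydrogen and methyl; with chloro as a third partner, compound 3 remains the only one of the four that gives a readable number, and no exception to this appears among the compounds shown. The steps among compound 1, compound 2 and compound 4 cannot be read, because each of them has the same limit at both ends, and that value is a limit of the assay and not a number: the limit of > 50000 nM in this assay, at which 3 of the 4 values shown sit.

Going by these compounds, whether the read value belongs to nitro alone remains open, since a nitrile, a carboxylic acid, an amine or a longer chain on this carbon could give a readable number or could stay at the limit. Also open, on these data alone, is whether hydrogen, methyl and chloro differ at all in this assay, as their true values lie beyond what the limit shows.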